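Phenoxy removal from the chain of compound 2

A few compounds are considered here, and "the series" means these few. Any claim that something is new, unique, unknown or untested is made for them only; others in the source may bear on it.

Among the compounds with values here, in a functional assay on HepG2 cells (Homo sapiens) for antiproliferative activity, read by MTT assay, with a stated time of 48 h (a higher number here means a weaker inhibitor of growth, a lower number a stronger inhibitor of growth), only two compounds have been measured so far. Compound 1 `Cc1ccc(-c2cnc(N(Cc3ccc(C(=O)NO)cc3)CC(C)C)s2)cc1` gives 7420 nM. Compound 2 `Cc1ccc(-c2cnc(N(CCCCOc3ccccc3)Cc3ccc(C(=O)NO)cc3)s2)cc1` gives 16600 nM, the higher of the two numbers and therefore the weaker inhibition of growth. Compound 3 `CCCCN(Cc1ccc(C(=O)NO)cc1)c1ncc(-c2ccc(C)cc2)s1` has not yet been measured. It differs from compound 2 as follows: hydrogen in place of phenoxy on a saturated chain carbon, four bonds along the chain from a nitrogen on an aromatic ring. In short, hydrogen stands in place of phenoxy on a saturated chain carbon, four bonds along the chain from a nitrogen on an aromatic ring.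

Within the data shown here, one measured step bears on this change: a 2.2-fold higher number from compound 1 to compound 2 (0.35 log units; beyond the scatter). That modest step has 3-phenoxypropyl in place of isopropyl, so it also introduces a phenoxy-bearing chain. The present change removes the phenoxy group, so a move of similar modest size in the opposite direction is expected. This rests on a single step between chains that are not the same as those in compound 3, so the basis is thin. The expected step is a 2.0-fold lower number from compound 2 to compound 3 (0.29 log units; within the scatter), towards a lower number in this assay. Compound 3 is estimated at 8500 nM, with an expected range of 3800 nM to 17000 nM.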

Compound 3, concentration for 50% growth inhibition: 4300 nM
Beside the measured number, compound 3's estimate is 2.0-fold (0.30 log units) above it; the range from low to high includes it.
By their numbers in this assay, from the lowest: compounds 3 and 1 (each within the scatter of the next); then compound 2.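

Working from this assay, removing phenoxy alone gives a 3.9-fold lower number from compound 2 to compound 3 (0.59 log units; beyond the scatter), a comparison in which the rest of the chain stays unbranched and only the phenoxy group leaves, which the earlier step from an isopropyl-type chain could not isolate. The step of a 1.7-fold lower number from compound 1 to compound 3 (0.24 log units; within the scatter), with propyl in place of isopropyl on a saturated chain carbon bound to a nitrogen on an aromatic ring, stays within the scatter, so these two compounds cannot be ordered and branching at this chain shows no readable effect here. Among the three compounds, the weakest growth inhibition therefore goes with the phenoxy-bearing chain of compound 2, though no measurement at hand gives a reason for this difference.

As far as these compounds go, it remains open whether the difference follows the aromatic ring or the ether oxygen of phenoxy; a terminal phenyl or a terminal methoxy on the same saturated chain carbon would separate the two. Also open, from the compounds shown here alone, is how an amine, a carboxylic acid or a longer unsubstituted chain at this place would compare with the plain chain of compound 3.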